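The compounds below may be only part of what the source reports. "The series", "measured", "known", "first", "only" and "open" are said of these compounds alone.

Measured so far:
- compound 1 `COc1cc(Cc2nc3c(N)nc(F)nc3n2CC2CCCO2)cc(OC)c1OC` — in a functional assay on MCF7 cells (Homo sapiens) for antiproliferative activity (a higher number here means a weaker inhibitor, a lower number a stronger inhibitor), compound 1 gives 22900 nM
- compound 2 `CC[C@H](C)Cn1c(Cc2cc(OC)c(OC)c(OC)c2)nc2c(N)nc(F)nc21` — in this assay compound 2 gives 43700 nM
- compound 3 `CCC(C)Cn1c(Cc2cc(OC)c(OC)c(OC)c2)nc2c(N)ncnc21` — in this assay compound 3 gives 61700 nM
- compound 4 `CCCn1c(Cc2cc(OC)c(OC)c(OC)c2)nc2c(N)nc(F)nc21` — not yet measured

Compound 2 stands second highest of the three numbers in this assay, but its distance to compound 3 and to compound 1 is within the scatter in each case, so no order among the three can be read from the data. Compound 3 differs from compound 2 in more than one place and is not a single step; its value merely sits close by.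

The change from compound 2 to compound 4 is hydrogen in place of ethyl on a saturated chain carbon bound to two saturated chain carbons. Going by the values given here, the one measured step touching the same saturated chain at the aromatic nitrogen, a 1.9-fold higher number from compound 1 to compound 2 (0.28 log units; within the scatter), was within the scatter. Nothing in the series shows that shortening this chain moves the number, so the step of a 1.0-fold higher number from compound 2 to compound 4 (0.01 log units; within the scatter) from compound 2 to compound 4 is expected to stay within the scatter, in no particular direction. Compound 4 is therefore estimated at 45000 nM, with a range of 18000 nM to 110000 nM.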

Compound 4, half-maximal inhibitory concentration: 25100 nM
Estimate against measurement, compound 4: 1.8-fold (0.25 log units) above; the range from low to high includes it.
By their numbers in this assay, from the lowest: compounds 1, 4, 2 and 3 (each within the scatter of the next, the first and the last beyond it).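

In this assay, the cut from 2-methylbutyl to propyl on the aromatic nitrogen gives a small step (a 1.7-fold lower number from compound 2 to compound 4 (0.24 log units; within the scatter)), so this change in chain length has no readable effect. The swap of oxolan-2-yl for ethyl on the saturated chain carbon bound to the aromatic nitrogen is also small (a 1.1-fold higher number from compound 1 to compound 4 (0.04 log units; within the scatter)), and the three substituents in compound 1, compound 2 and compound 4 cannot be told apart at this position. No data are available that bear on the reason for this result.

From the compounds shown here alone, whether any group at this position can move the number beyond the scatter remains open. A longer chain such as n-hexyl, or a chain ending in an amine or a carboxylic acid, would test this with the rest of compound 4 kept unchanged.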